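The source may report more compounds than this note shows. Statements on the series, on what has been measured and on what is new or still open speak of the compounds shown alone.

Measured so far:
- compound 1, `CC(=O)Nc1c(C(O)(C(F)(F)F)C(F)(F)F)ccc2ccccc12`: 18 nM
- compound 2, `O=C(Nc1c(C(O)(C(F)(F)F)C(F)(F)F)ccc2ccccc12)C1CC1`: 751 nM
- compound 3, `CC(C)OC(=O)Nc1c(C(O)(C(F)(F)F)C(F)(F)F)ccc2ccccc12`: 1160 nM

All three share one core and differ only in the group on the carbonyl carbon of the amide. In an assay on LtK cells with ATP-sensitive inward rectifier potassium channel 11 (Homo sapiens) as the target (on this read-out lower numbers stand for an effect already at smaller amounts and higher numbers for an effect only at larger amounts of compound), compound 3 gives the highest number of the three, so it acts only at the largest amounts; its nearest neighbour is compound 2 (a 1.5-fold higher number from compound 2 to compound 3 (0.19 log units; within the scatter)), while compound 1 lies far off (a 64-fold higher number from compound 1 to compound 3 (1.81 log units; beyond the scatter)).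

Compound 4, `Cc1cccc(C(=O)Nc2c(C(O)(C(F)(F)F)C(F)(F)F)ccc3ccccc23)c1`, takes the next step: 3-methylphenyl in place of isopropoxy on a carbonyl carbon.

For the measured compounds named here, no measured step covers this exact exchange. What bears on it are the two steps away from the small methyl of compound 1: a 42-fold higher number from compound 1 to compound 2 (1.62 log units; beyond the scatter) and a 64-fold higher number from compound 1 to compound 3 (1.81 log units; beyond the scatter), both large and both in the direction of weaker binding, whereas the step between the two larger groups, a 1.5-fold higher number from compound 2 to compound 3 (0.19 log units; within the scatter), stays within the scatter. A 3-methylphenyl is again a sizable group, so compound 4 is expected to land near compound 3, with a step of a 1.7-fold higher number from compound 3 to compound 4 (0.24 log units; within the scatter) in this assay. The estimate for compound 4 is 2000 nM, with a range from 500 nM to 10000 nM.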

Compound 4, half-maximal effective concentration: 23 nM
Estimate against measurement, compound 4: 87-fold (1.94 log units) above; the whole stated range lies above it.
By their numbers in this assay, from the lowest: compounds 1 and 4 (each within the scatter of the next); then compounds 2 and 3 (each within the scatter of the next).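

For the compounds shown here, compound 4 breaks the impression left by the earlier compounds that any group on this carbonyl carbon with more heavy atoms than methyl sends the number up. The exchange of isopropoxy for 3-methylphenyl gives a 50-fold lower number from compound 3 to compound 4 (1.70 log units; beyond the scatter) in this assay, and the exchange of cyclopropyl for 3-methylphenyl gives a 33-fold lower number from compound 2 to compound 4 (1.51 log units; beyond the scatter) in the same test. Set against the small methyl, 3-methylphenyl gives a 1.3-fold higher number from compound 1 to compound 4 (0.11 log units; within the scatter), so a group carrying a six-membered aromatic ring can sit at this position and still match compound 1, and no measurement at hand explains this.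

On these data alone, whether a plain phenyl without the methyl would keep the number of compound 4 remains open. So does the behaviour of a pyridine ring, an amine or a longer alkyl chain at this position.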